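Working notes on three measured analogues and one to come

A few compounds are considered here, and "the series" means these few. Any claim that something is new, unique, unknown or untested is made for them only; others in the source may bear on it.

Measured so far in a functional assay on the whole organism (strain albino) for inhibition, with Rattus norvegicus as the target, read by paw edema, with stated times of 30 min and 2 h, at a dose of 100 mg/kg by the oral route; on this read-out higher numbers stand for more inhibition at the one dose given (going by the name of the read-out) and lower numbers for less inhibition:
compound 1, `COc1ccc(C2CC(c3ccc(OC)c(OC)c3)=NN2C(=O)CO[N+](=O)[O-])c(OC)c1`: 48%
compound 2, `COc1ccc(C2=NN(C(=O)CO[N+](=O)[O-])C(c3c(Cl)cccc3Cl)C2)cc1OC`: 49%
compound 3, `COc1ccc(C2=NN(C(=O)CO[N+](=O)[O-])C(c3c(Cl)cccc3Cl)C2)cc1`: 42%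

Compound 2 carries the highest of the three numbers, but its steps to the other two are within the scatter: a number 1 percentage points higher from compound 1 to compound 2 (within the scatter), with 2,6-dichlorophenyl in place of 2,4-dimethoxyphenyl on a saturated ring carbon, and a number 7 percentage points lower from compound 2 to compound 3 (within the scatter), with hydrogen in place of methoxy on an aromatic carbon. Neither step points to a real difference among the three.

The next compound is compound 4, `COc1ccc(C2=NN(C(=O)C(C)Br)C(c3c(Cl)cccc3Cl)C2)cc1OC`. It differs from compound 2 as follows: 1-bromoethyl in place of (nitrooxy)methyl on a carbonyl carbon. Among the measured compounds shown here, both measured steps touch the aryl rings; none touches the carbonyl carbon, so no measured step bears directly on this change. For the measured compounds named here, the three numbers so far sit in a narrow band, and with no information on the acyl group the expectation is a step no larger than the scatter: a number 4 percentage points lower from compound 2 to compound 4 (within the scatter) is the estimated step. For compound 4 in this assay the estimate is 45%, with a range from 28% to 62%.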

Compound 4, a percentage reported as inhibition, in the whole organism at one dose (the size of the read-out at that dose, not a potency): 56%
Estimate against measurement, compound 4: 11 percentage points below; the range from low to high includes it.
By their numbers in this assay, from the lowest: compounds 3, 1, 2 and 4 (each within the scatter of the next, the first and the last beyond it).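

Among the compounds shown here, this is the first look at the group on the carbonyl carbon, and with 1-bromoethyl in place of (nitrooxy)methyl there is a number 7 percentage points higher from compound 2 to compound 4 (within the scatter) in this assay. The read-out at this position therefore survives the loss of the (nitrooxy)methyl group in this one pair, and a group with no hydrogen-bond acceptors counted serves as well here as one with acceptors. No measurement shown offers an explanation for this result.

A single exchange cannot show whether other groups on this carbonyl carbon would give a step beyond the scatter, for example bromomethyl, a longer chain, an amine or a carboxylic acid. On these data alone, it also remains open whether 1-bromoethyl would behave the same way with the aryl rings of compound 1 or compound 3.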